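The source may hold more compounds than are shown below. What is called first, only, known or untested is meant among the compounds shown, and "the series" means these compounds.

The series shares one core, carrying a five-membered aromatic ring with a variable aryl group. Compound 1 `O=c1ccc2cc(OCc3cc(-c4ccccc4Cl)no3)ccc2o1` bears a 2-chlorophenyl group there; in a functional assay on HL-60 cells (Homo sapiens) for cytotoxicity, read by MTT assay, with a stated time of 48 h (a lower number here means a stronger inhibitor, a higher number a weaker inhibitor), compound 1 returns "not determined" (no result reported), so no number stands for it. Compound 3 `COc1cccc(-c2cc(COc3ccc4oc(=O)ccc4c3)on2)c1` likewise returns "not determined" (no result reported) in this assay. Within the data shown here, the only number in the set belongs to compound 2 `O=c1ccc2cc(OCc3cc(-c4cccc5ccccc45)no3)ccc2o1`, which in this assay gives 41600 nM, a weak result.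

Compound 4 `O=c1ccc2cc(OCc3cc(-c4cccc(Cl)c4)no3)ccc2o1` has not been measured. It differs from compound 1 in one place (3-chlorophenyl in place of 2-chlorophenyl on an aromatic carbon). Among the measured compounds shown here, with no number for compound 1, the size and direction of the step cannot be drawn from the data; the only anchor is compound 2, and compound 4 is expected to land in the same weak region, with no step beyond the usual scatter relative to that anchor. Compound 4 is therefore estimated at 35000 nM in this assay, in the range from 9000 nM to 130000 nM.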

Compound 4, half-maximal inhibitory concentration: 50600 nM
Estimate against measurement, compound 4: 1.4-fold (0.16 log units) below; the measured number falls inside the stated range.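

Among these compounds, compound 1 has no single number in this assay, so no step to compound 4 can be read. The compounds shown leave open whether 2-chlorophenyl and 3-chlorophenyl differ in this cytotoxicity read-out. No evidence on hand bears on the result.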